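Anilino in place of methoxy on the shared core

A few compounds are considered here, and "the series" means these few. Any claim that something is new, unique, unknown or untested is made for them only; others in the source may bear on it.

In a functional assay on SEM cells (Homo sapiens) for cytotoxicity, with a stated time of 72 h (a higher number here means that more compound is needed for the effect, a lower number that less compound is needed), compound 1 (`C=C[C@@](C)(/C=C/c1ccc(OC)cc1)CCC=C(C)C`) gives > 36600 nM, which is a limit of the assay and not a number. Compound 2 (`C=C[C@@](C)(/C=C/c1ccc(O)c(/C=C/C#N)c1)CCC=C(C)C`) gives > 36600 nM, also a limit. For the measured compounds named here, neither compound has a measured number, so the two cannot be ranked, and no measured step exists to set a size. Going by the values given here, the only firm reading is the limit of > 36600 nM in this assay, at which 2 of the 2 values shown sit.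

Compound 3 (`C=C[C@@](C)(/C=C/c1ccc(Nc2ccccc2)cc1)CCC=C(C)C`) keeps the core of compound 1 and carries one change: anilino in place of methoxy on an aromatic carbon, para to a large group (anilino in place of methoxy on an aromatic carbon). With compound 1 at > 36600 nM, the expectation in this assay is a small step toward less compound needed, or none beyond the scatter, and the most likely outcome is another limit. The expected change is an at least 1.3-fold lower number from compound 1 to compound 3 (0.11 log units; that floor lies within the scatter), and it is a weakly supported estimate. For compound 3 the estimated value is 28000 nM, with an expected range of 9000 nM to 60000 nM.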

Compound 3, half-maximal effective concentration: > 36600 nM
Compound 3 was reported as a limit; the forecaster's own chance of this, stated with the estimate: 70%; middle value at least 1.3-fold (0.11 log units) away from the limit.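

Compound 1 and compound 3 are both reported only as limits in this assay, so the swap of methoxy for anilino gives no readable step: the limit of > 36600 nM in this assay, at which 3 of the 3 values shown sit.

The compounds shown leave open how anilino and methoxy compare on the shared core, and whether any change to that core gives a measured number in this assay.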